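A few compounds are considered here, and "the series" means these few. Any claim that something is new, unique, unknown or untested is made for them only; others in the source may bear on it.

Measured compounds:
Compound 1, `CC(C)N(Cc1cccc(OCCCCCC(=O)O)c1)C(=O)c1ccc(-c2cccc(-c3ccccc3)c2)cc1`, in an ADME assay on BJ cells (Homo sapiens) for cytotoxicity, read by CellTiter-Glo and resazurin assay, with a stated time of 72 h (on this read-out lower numbers stand for an effect already at smaller amounts and higher numbers for an effect only at larger amounts of compound), gives > 26000 nM, which is a limit of the assay.
Compound 2, `CC(C)COc1cccc(-c2ccc(C(=O)N(Cc3cccc(OCCCCCC(=O)O)c3)C(C)C)cc2)c1`, in this assay gives > 26000 nM, also a limit.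
Compound 3, `CC(C)N(Cc1cccc(OCCCCCC(=O)O)c1)C(=O)c1ccc(-c2cccc(Oc3ccccc3)c2)cc1`, in this assay gives > 18700 nM, again a limit.

Compound 3 thus stands only at a limit, as do the other two, so no order among them can be read. Compound 4, `CC(C)N(Cc1cccc(OCCCCCC(=O)O)c1)C(=O)c1ccc(-c2cccc(OCc3ccccc3)c2)cc1`, differs from compound 3 by benzyl in place of phenyl on an oxygen on an aromatic ring. The measured steps a step that the two limits leave unreadable from compound 1 to compound 2, a step that the two limits leave unreadable from compound 1 to compound 3 and a step that the two limits leave unreadable from compound 2 to compound 3 are all unreadable, since the limit of > 18700 nM in this assay, at which 1 of the 3 values shown sits, and the limit of > 26000 nM in this assay, at which 2 of the 3 values shown sit, cap every value. Nothing therefore points to a step beyond the scatter, and compound 4 is expected to give only a limit again. The step expected here is a step that the limit leaves unreadable from compound 3 to compound 4. The estimate for compound 4 is 30000 nM, within 15000 nM to 80000 nM.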

Compound 4, half-maximal effective concentration: > 26000 nM
Compound 4: a limit, no number; the forecaster's own chance of this, stated with the estimate: 85%; the middle value does not contradict the limit.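

Among these compounds, compound 1, compound 2, compound 3 and compound 4 all give only limits in this assay, so no step among them can be read. The compounds shown leave open at what concentration any of them reaches its half-maximal effect on these cells.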